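The compounds below may be only part of what the source reports. "The series", "measured", "known", "first", "only" and "open" are said of these compounds alone.

Two compounds have been measured in an ADME assay on Vero cells (Chlorocebus sabaeus) for cytotoxicity, with a stated time of 7 days; a higher number here means that more compound is tolerated, a lower number that less compound is tolerated:

Compound 1 `O=C(c1cc2cc(C3CC3)ccc2[nH]1)N1CC(=O)N(Cc2ccccc2)[C@@H](CN2CCN(Cc3ccccc3)CC2)C1`: 5500 nM
Compound 2 `COc1ccc2[nH]c(C(=O)N3CC(=O)N(Cc4ccccc4)[C@@H](COC(C)(C)C)C3)cc2c1`: 78200 nM

Of the two numbers in this assay, compound 2 stands highest, with compound 1 the nearest and the only other point; the gap between them lies beyond the usual scatter of repeated measurements, so compound 2 is the better tolerated of the pair. Going by the values given here, no single-change step between measured compounds is available, and compound 1 differs from compound 2 in more than one place, so the two values show only that the compounds sit far apart.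

Compound 3 `COc1ccc2[nH]c(C(=O)N3CC(=O)N(Cc4ccccc4)[C@@H](CN4CC5CC5C4)C3)cc2c1` has not yet been measured. It differs from compound 2 as follows: a group of 6 heavy atoms (5 carbon, 1 nitrogen; one three-membered non-aromatic ring of carbon only, one five-membered non-aromatic ring with 1 hetero atom) in place of a group of 5 heavy atoms (4 carbon, 1 oxygen; no ring), on a saturated chain carbon bound to a saturated ring carbon. Compound 3 shares with compound 1 the feature that a nitrogen-containing group sits at this position, and because compound 1 gives 5500 nM in this assay, a move away from compound 2 toward less tolerance is expected, with the step of a 3.9-fold lower number from compound 2 to compound 3 (0.59 log units; beyond the scatter) estimated to lie beyond the scatter. For compound 3 the expected value in this assay is 20000 nM, within a range from 6000 nM to 60000 nM.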

Compound 3, half-maximal cytotoxic concentration: 13800 nM
Beside the measured number, compound 3's estimate is 1.4-fold (0.16 log units) above it; measured number inside the range.
By their numbers in this assay, from the lowest: compound 1; then compound 3; then compound 2.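

In this assay, going by these compounds alone, the replacement of tert-butoxy by the nitrogen-containing two-ring group, on a saturated chain carbon bound to a saturated ring carbon, gives the first single-change reading at this position: a 5.7-fold lower number from compound 2 to compound 3 (0.75 log units; beyond the scatter). The position therefore influences how much compound the cells tolerate, which the earlier pair could not show, as those two compounds differ in more than one place. The two groups have the same hydrogen-bond donor and acceptor counts and neither carries a net charge, so those counts do not separate them, and no measurement available here bears on the reason for the step.

The compounds shown leave open whether the lower number goes with the nitrogen or with the ring system, a question that an open-chain amine such as diethylamino or an oxygen-linked ring such as cyclopentyloxy at this position could help to settle. As far as these compounds go, it also remains open how much of the value of compound 1, 5500 nM, comes from this position, since its benzylpiperazine group is not the only place where it differs from compound 3.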